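The source may hold more compounds than are shown below. What is called first, only, known or untested is meant among the compounds shown, and "the series" means these compounds.

Compound 1 `CNC(=O)c1c(-c2ccc(F)cc2)oc2ccc(-c3cccc(C(=O)NC4(c5ccccn5)CC4)c3)cc12` gives 54% in an ADME assay on microsomes from liver (Rattus norvegicus) for metabolic stability; a higher number here means that more of the compound is left, a lower number that less of the compound is left. Compound 2 `CNC(=O)c1c(-c2ccc(F)cc2)oc2cc(N(CCO)S(C)(=O)=O)c(-c3cccc(C(=O)NC4(c5ccccn5)CC4)c3)cc12` gives 8.7% in this assay, the lowest of the two numbers shown, set there by the step of a number 45.3 percentage points lower from compound 1 to compound 2 (beyond the scatter). Compound 3 `CNC(=O)c1c(-c2ccc(F)cc2)oc2cc(N(CCO)S(C)(=O)=O)c(-c3cccc(C(=O)NC4(c5ccccc5)CC4)c3)cc12` differs from compound 2 by phenyl in place of pyridin-2-yl on a saturated ring carbon. Among the measured compounds shown here, no measured step concerns this change; the only step known, a number 45.3 percentage points lower from compound 1 to compound 2 (beyond the scatter), alters a different part of the shared core and offers no guide. The change from compound 2 to compound 3 is therefore expected to give no step beyond the scatter, a number 1.3 percentage points higher from compound 2 to compound 3 (within the scatter). For compound 3 the estimate in this assay is 10%, with a range from 3% to 25%.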

Compound 3, percent of the compound remaining: 0.6%
For compound 3 the middle estimate is 9.4 percentage points above the measured one; the measured number lies below the stated range.
By their numbers in this assay, from the lowest: compounds 3 and 2 (each within the scatter of the next); then compound 1.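

In this assay, the swap of pyridin-2-yl for phenyl on the saturated ring carbon gives a number 8.1 percentage points lower from compound 2 to compound 3 (within the scatter) and so does not separate the two compounds. With the (2-hydroxyethyl)(methylsulfonyl)amino group in place, this position shows no step beyond the scatter on loss of the ring nitrogen, although both values are so low that little room remains for a downward step to show. No measurement bearing on the reason accompanies this result.

On these data alone, it remains open whether 1-phenylcyclopropyl and 1-(pyridin-2-yl)cyclopropyl would differ without the (2-hydroxyethyl)(methylsulfonyl)amino group. Also open, as far as these compounds go, is how an amine or a carboxylic acid on this ring would read.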